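The source may report more compounds than this note shows. Statements on the series, on what has been measured and on what is new or still open speak of the compounds shown alone.

Series notes. The shared core is carried by compound 1 `CC1CC/C(=N\Nc2ccc(F)cc2)c2ncc(C(=O)O)c(=O)n21`, compound 2 `CC1CC/C(=N\Nc2ccc(O)cc2)c2ncc(C(=O)O)c(=O)n21` and compound 3 `Cc1ccc(N/N=C2\CCC(C)n3c2ncc(C(=O)O)c3=O)cc1`, which differ from one another only in the group on an aromatic carbon of the outer ring. In a functional assay on the whole organism for inhibition, with Rattus norvegicus as the target (on this read-out higher numbers stand for an effect only at larger amounts of compound and lower numbers for an effect already at smaller amounts), compound 1 gives 12.2 umol/kg, compound 2 gives 1.7 umol/kg and compound 3 gives 1.3 umol/kg. Two steps are beyond the scatter: a 7.2-fold lower number from compound 1 to compound 2 (0.86 log units; beyond the scatter) and a 9.4-fold lower number from compound 1 to compound 3 (0.97 log units; beyond the scatter). The third, a 1.3-fold lower number from compound 2 to compound 3 (0.12 log units; within the scatter), is within the scatter. Compound 3 therefore has the lowest of the three numbers, but compound 2 sits within the scatter of it, so no order between those two can be read.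

Compound 4 `CC1CC/C(=N\Nc2ccc(-c3ccccc3)cc2)c2ncc(C(=O)O)c(=O)n21` is not yet measured. It differs from compound 3 by phenyl in place of methyl on an aromatic carbon. Going by the values given here, no measured step involves a phenyl at this place; the measured steps concern fluoro, hydroxy and methyl there, and they show that hydroxy and methyl give numbers within the scatter of each other while fluoro gives a higher one. Whether a much larger group behaves like methyl is not told by these data, so the expectation for compound 4 in this assay is a step of a 1.9-fold higher number from compound 3 to compound 4 (0.28 log units; within the scatter), not beyond the scatter, with wide uncertainty. Compound 4 is thus estimated at 2.5 umol/kg, with a range from 0.8 umol/kg to 8 umol/kg.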

Compound 4, dose for 50% inhibition: 1.1 umol/kg
The estimate for compound 4 lay 2.3-fold (0.36 log units) above the measured number; the range from low to high includes it.
By their numbers in this assay, from the lowest: compounds 4, 3 and 2 (each within the scatter of the next); then compound 1.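

In this assay, the place on an aromatic carbon para to a large group accepts phenyl, with its 6 heavy atoms and a six-membered aromatic ring, in place of methyl, with 1 heavy atom, without a step beyond the scatter: a 1.2-fold lower number from compound 3 to compound 4 (0.07 log units; within the scatter). The comparison with hydroxy gives the same reading, a 1.5-fold lower number from compound 2 to compound 4 (0.19 log units; within the scatter), so among these compounds the read-out does not separate phenyl, methyl and hydroxy, and the larger group extends what the earlier small groups could show; fluoro alone stands apart, with an 11-fold lower number from compound 1 to compound 4 (1.04 log units; beyond the scatter), the only step in this set marked as large. No measurement available here bears on why fluoro differs or why the change from methyl to phenyl leaves the number within the scatter.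

Still open, as far as these compounds go, is whether an amine, a carboxylic acid or a longer alkyl chain at this place would stay with hydroxy, methyl and phenyl or move towards fluoro. Also open, from the compounds shown here alone, is whether the same reading would hold with ethyl in place of the methyl on the shared core.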